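The source may report more compounds than this note shows. Statements on the series, on what has been measured and on what is new or still open speak of the compounds shown alone.

Measured in an ADME assay on MDBK cells (Bos taurus) for cytotoxicity, read by MTT assay, with a stated time of 96 h; on this read-out higher numbers stand for lower toxicity in this test and lower numbers for higher toxicity in this test:
- Compound 1 `Fc1ccc(F)c(/N=N/c2ccc(NC[C@@H]3CCCN4CCCC[C@H]34)c3c2CCCC3)c1`: 64000 nM
- Compound 2 `Brc1cccc(/N=N/N2CCCCC2)c1`: > 100000 nM (a limit of the assay)

Among the measured compounds shown here, compound 1 holds the only actual number in this assay, and the reading for compound 2 is a limit, not a number. Compound 3 `FC(F)(F)c1cccc(/N=N/c2ccc(NC[C@@H]3CCCN4CCCC[C@H]34)c3c2CCCC3)c1` keeps the core of compound 1 but has 3-(trifluoromethyl)phenyl in place of 2,5-difluorophenyl on a double-bonded nitrogen. For the measured compounds named here, no measured pair shows what this swap does, so no change beyond the usual scatter is expected in this assay. This expectation rests on compound 1 alone, at 64000 nM. The estimated step of a 1.3-fold lower number from compound 1 to compound 3 (0.11 log units; within the scatter) is therefore small. Compound 3 is expected at 50000 nM, within an estimated range of 22000 nM to 100000 nM.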

Compound 3, half-maximal cytotoxic concentration: 30000 nM
Compound 3: middle estimate off by 1.7-fold (0.22 log units), on the high side, and the stated range covers the measured number.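

In this assay, putting 3-(trifluoromethyl)phenyl in place of 2,5-difluorophenyl on a double-bonded nitrogen gives a 2.1-fold lower number from compound 1 to compound 3 (0.33 log units; beyond the scatter). This shows that the group at this place is not silent on the shared core: the swap moves the reading modestly towards higher toxicity in this test. Compound 2 reads only as a limit and so enters no step: the limit of > 100000 nM in this assay, at which 1 of the 3 values shown sits.

From the compounds shown here alone, the swap removes the fluorines of 2,5-difluorophenyl and brings in trifluoromethyl at once, so which of the two carries the step stays open. Also open, going by these compounds, is how a phenyl bearing an amine or a carboxylic acid would read here.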